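Aryl amine variation on the shared core: toward compound 4

This account rests on a few compounds, and the source may have more. Where it says the series, first, only, none or still open, it means among the compounds named here.

Among the compounds with values here, the three measured members share one core and differ only in the aryl group on one nitrogen. Compound 1 `Fc1cc(F)c(Nc2nc3nonc3nc2Nc2c(F)cc(F)cc2F)c(F)c1` gives 1100 nM in an assay on mitochondria from L6 cells (Rattus norvegicus) for activation, with a stated time of 90 min; a higher number here means that more compound is needed for the effect, a lower number that less compound is needed. Compound 2 `Fc1cccc(Nc2nc3nonc3nc2Nc2ccccc2F)c1` gives 190 nM in this assay, and compound 3 `Fc1ccc(Nc2nc3nonc3nc2Nc2ccccc2F)cc1` gives 2300 nM. Compound 3 therefore stands highest of the three numbers, with compound 1 nearest and compound 2 furthest away. Within the data shown here, the only single-point step among the measured compounds, a 12-fold higher number from compound 2 to compound 3 (1.08 log units; beyond the scatter), is large.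

Compound 4 `Cc1cccc(Nc2nc3nonc3nc2Nc2ccccc2F)c1` is not yet measured. It differs from compound 3 by 3-methylphenyl in place of 4-fluorophenyl on a nitrogen on an aromatic ring. Among the measured compounds shown here, no measured pair sets 3-methylphenyl against 4-fluorophenyl, so the change is covered only in part: the step of a 12-fold higher number from compound 2 to compound 3 (1.08 log units; beyond the scatter) exchanged 3-fluorophenyl for 4-fluorophenyl, and the change to compound 4 runs that exchange the other way while also putting methyl where fluorine stood. Because compound 2 carrying 3-fluorophenyl gives 190 nM, compound 4 is expected to come down by about a 6.6-fold lower number from compound 3 to compound 4 (0.82 log units; beyond the scatter). For the measured compounds named here, the fluorine-to-methyl part of the change has no precedent here and widens the range. Compound 4 is estimated at 350 nM, within 100 nM to 1200 nM.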

Compound 4, half-maximal effective concentration: 1500 nM
For compound 4 the middle estimate is 4.3-fold (0.63 log units) below the measured one, outside the stated range (above it).
By their numbers in this assay, from the lowest: compound 2; then compounds 1, 4 and 3 (each within the scatter of the next, the first and the last beyond it).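

Replacing fluoro with methyl on an aromatic carbon gives a 7.9-fold higher number from compound 2 to compound 4 (0.90 log units; beyond the scatter), so in this assay the low number of compound 2 does not follow from the 3-substituted phenyl pattern alone and depends on which group is present, at least for these two groups. The other new step, a 1.5-fold lower number from compound 3 to compound 4 (0.19 log units; within the scatter), lies within the scatter, so 3-methylphenyl and 4-fluorophenyl on this nitrogen cannot be told apart here, and among the three compounds that differ only in this aryl group, compound 2 alone stands apart, with both a 12-fold higher number from compound 2 to compound 3 (1.08 log units; beyond the scatter) and the step to compound 4 beyond the scatter. No separate evidence bears on why fluoro and methyl differ at this place.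

The compounds shown leave open whether any group other than fluoro can hold the number of compound 2 at this place, for example chloro, methoxy, an amine or a carboxylic acid. They also leave open whether the gap between 3-fluorophenyl and 3-methylphenyl persists when the aryl group on the other nitrogen of the shared core is changed.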